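Swapping Cyano for Isopropyl in a Seizure Model

This account rests on a few compounds, and the source may have more. Where it says the series, first, only, none or still open, it means among the compounds named here.

Of the compounds shown here, two have been tested in a functional assay on the whole organism with Mus musculus as the target, in the maximal electroshock model, with a stated time of 30 min; on this read-out lower numbers stand for an effect already at smaller amounts and higher numbers for an effect only at larger amounts of compound. Compound 1 `Cc1cc(Oc2ccccc2)c[n+]([O-])c1` gives 100 mg/kg. Compound 2 `N#Cc1cc[n+]([O-])cc1Oc1ccccc1` gives 300 mg/kg, the higher of the two numbers, and its gap from compound 1 lies beyond the usual scatter. Compound 3 `CC(C)c1cc[n+]([O-])cc1Oc1ccccc1` differs from compound 2 in one place: isopropyl in place of cyano on an aromatic carbon. For the measured compounds named here, no measured pair shows this exact change, so the expectation rests on the two values alone. Compound 3 is expected to work at a somewhat smaller amount than compound 2, a step of a 2.0-fold lower number from compound 2 to compound 3 (0.30 log units; within the scatter) toward lower numbers, near the edge of the scatter. The estimate for compound 3 is 150 mg/kg, with a range from 50 mg/kg to 400 mg/kg.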

Compound 3, minimum effective dose: 30 mg/kg
For compound 3 the middle estimate is 5.0-fold (0.70 log units) above the measured one; the measured number lies below the stated range.
By their numbers in this assay, from the lowest: compound 3; then compound 1; then compound 2.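

The change from cyano to isopropyl on this aromatic carbon, opposite the ring nitrogen, gives (a 10-fold lower number from compound 2 to compound 3 (1.00 log units; beyond the scatter)), well beyond the scatter. The earlier compounds shown here could not show this: the group at this one position strongly affects the dose needed, with the rest of the structure unchanged. No available evidence explains the size of this step.

The compounds shown leave open whether isopropyl is special or whether other groups here, such as a longer chain, an amine or a carboxylic acid, would work as well.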